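The source may hold more compounds than are shown below. What is called first, only, known or untested is meant among the compounds shown, and "the series" means these compounds.

Three compounds share one core and differ only in the group carried on an amine nitrogen in a ring. Compound 1 `Nc1ccccc1NC(=O)c1ccc(CSC(=S)N2CCN(Cc3ccncc3)CC2)cc1` gives 72.9% in a functional assay on HeLa cells (Homo sapiens) for antiproliferative activity, read by CCK-8 assay, with a stated time of 72 h, tested at 8 uM; a higher number here means a stronger effect of the compound at the concentration tested, a lower number a weaker effect. Compound 2 `Nc1ccccc1NC(=O)c1ccc(CSC(=S)N2CCN(c3ccccc3F)CC2)cc1` gives 59.2% in this assay, and compound 3 `Nc1ccccc1NC(=O)c1ccc(CSC(=S)N2CCc3ccccc32)cc1` gives 67% there. Compound 2 thus stands lowest of the three numbers; its nearest neighbour is compound 3, within the scatter, while its gap to compound 1 lies beyond the scatter. Compound 4 `Cc1ccc(N2CCN(C(=S)SCc3ccc(C(=O)Nc4ccccc4N)cc3)CC2)cc1` has not yet been measured in this assay. It differs from compound 2 in one place: 4-methylphenyl in place of 2-fluorophenyl on an amine nitrogen in a ring. Going by the values given here, the only measured step at this same place, a number 13.7 percentage points lower from compound 1 to compound 2 (beyond the scatter), was modest. Among the compounds with values here, no measured step exchanges one aryl group on that nitrogen for another, so the data do not show how large such an exchange is. Compound 4 is therefore expected to give about 60% in this assay, with a range from 45% to 75%. The expected step, a number 0.8 percentage points higher from compound 2 to compound 4 (within the scatter), is estimated to stay within the scatter.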

Compound 4, a percentage reported as inhibition, at one concentration (the size of the read-out at that concentration, not a potency): 24%
Compound 4: middle estimate off by 36 percentage points, on the high side, and the stated range ends above it.
By their numbers in this assay, from the lowest: compound 4; then compounds 2, 3 and 1 (each within the scatter of the next, the first and the last beyond it).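

The aryl group on this amine nitrogen is not freely exchangeable. In this assay, 4-methylphenyl in place of 2-fluorophenyl gives a number 35.2 percentage points lower from compound 2 to compound 4 (beyond the scatter), although both groups have the same heavy-atom count and one six-membered aromatic ring of carbon only. This large step exceeds the modest one seen earlier at this place, a number 13.7 percentage points lower from compound 1 to compound 2 (beyond the scatter), and 4-methylphenyl in place of (pyridin-4-yl)methyl gives a number 48.9 percentage points lower from compound 1 to compound 4 (beyond the scatter), so a change between aryl groups here can matter more than one from a (pyridin-4-yl)methyl group to an aryl group. Nothing available explains this drop.

The two aryl groups differ both in their substituent and in where it sits on the ring, and the compounds shown do not separate these two changes. On these data alone, how a plain phenyl group, or a phenyl group carrying chlorine or methoxy, would compare also remains open.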